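Thioamide in place of nitrile on the shared core

The source may report more compounds than this note shows. Statements on the series, on what has been measured and on what is new or still open speak of the compounds shown alone.

Measured so far:
compound 1 `Cc1cccc(Cn2cc(C(=N)S)c3c(N)ncnc32)c1` gives 30000 nM in a functional assay on KB cells (Homo sapiens) for cytotoxicity; on this read-out lower numbers stand for stronger inhibition and higher numbers for weaker inhibition
compound 2 `CC(C)(C)c1ccc(Cn2cc(C(=N)S)c3c(N)ncnc32)cc1` gives 7000 nM in this assay
compound 3 `Cc1ccc(Cn2cc(C#N)c3c(N)ncnc32)cc1` gives > 100000 nM in this assay

Compound 3 sits at a limit of this assay, not at a number (the limit of > 100000 nM in this assay, at which 1 of the 3 values shown sits). Compound 1 and compound 2, which carry the entering group, both give numbers. Compound 4 `Cc1ccc(Cn2cc(C(=N)S)c3c(N)ncnc32)cc1` has not been measured in this assay. Compound 4 differs from compound 3 by a group of 3 heavy atoms (1 carbon, 1 nitrogen, 1 sulfur; no ring) in place of a group of 2 heavy atoms (1 carbon, 1 nitrogen; no ring), on an aromatic carbon. Among the measured compounds shown here, no step between measured compounds is known, so the size of this one is not fixed; the expected direction is toward lower numbers, beyond the scatter, given that compound 1 gives 30000 nM and compound 2 gives 7000 nM in this assay. For compound 4 the estimate in this assay is 20000 nM, between 6000 nM and 60000 nM. The expected step is an at least 5.0-fold lower number from compound 3 to compound 4 (0.69 log units; beyond the scatter).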

Compound 4, half-maximal inhibitory concentration: 65000 nM
Compound 4: middle estimate off by 3.3-fold (0.51 log units), on the low side; the whole stated range lies below it.
By their numbers in this assay, from the lowest: compound 2; then compound 1; then compound 4. At a limit, above all of these: compound 3.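

Compound 3 stands at a limit of this assay, not at a number: the limit of > 100000 nM in this assay, at which 1 of the 4 values shown sits.

The change from cyano to the thioamide group therefore fixes only a floor, an at least 1.5-fold lower number from compound 3 to compound 4 (0.18 log units; that floor lies within the scatter), and does not by itself establish a change beyond the scatter. With the thioamide kept, the number still moves with the other group: methyl in place of tert-butyl gives a 9.3-fold higher number from compound 2 to compound 4 (0.97 log units; beyond the scatter), and 4-methylphenyl in place of 3-methylphenyl gives a 2.2-fold higher number from compound 1 to compound 4 (0.34 log units; beyond the scatter).

As far as these compounds go, the true size of the step from cyano to thioamide stays open. So does how a carboxylic acid or an amine on this aromatic carbon would read in this assay.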